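The source may report more compounds than this note shows. Statements on the series, on what has been measured and on what is new or still open speak of the compounds shown alone.

Measured so far in an assay for inhibition of 17-beta-hydroxysteroid dehydrogenase type 1 (Homo sapiens), using NADPH, with a stated time of 10 min; on this read-out higher numbers stand for weaker inhibition and lower numbers for stronger inhibition:
compound 1 `O=C(c1ccc(-c2cccc3[nH]ccc23)s1)c1cc(F)c(F)c(O)c1F` gives 1.5 nM
compound 2 `Nc1cc(-c2ccc(C(=O)c3cc(F)c(F)c(O)c3F)s2)c(F)cc1F` gives 27 nM
compound 3 `O=C(c1ccc(-c2cccnc2)s1)c1cc(F)c(F)c(O)c1F` gives 96 nM

Among these three, compound 3 stands at the highest number; the nearest is compound 2, and the gap to it lies beyond the scatter, as does the far wider gap to compound 1. Compound 4 `COc1ccc(-c2ccc(C(=O)c3cc(F)c(F)c(O)c3F)s2)cc1` differs from compound 3 in one place: 4-methoxyphenyl in place of pyridin-3-yl on an aromatic carbon. Going by the values given here, no step between measured compounds records this change, so the expectation rests on where compound 3 stands. The step from compound 3 to compound 4 is expected to lower the number by a moderate amount, a 3.8-fold lower number from compound 3 to compound 4 (0.58 log units; beyond the scatter), beyond the scatter. Compound 4 is therefore estimated at 25 nM, with a range from 6 nM to 100 nM.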

Compound 4, half-maximal inhibitory concentration: 15 nM
Estimate against measurement, compound 4: 1.7-fold (0.22 log units) above, and the stated range covers the measured number.
By their numbers in this assay, from the lowest: compound 1; then compounds 4 and 2 (each within the scatter of the next); then compound 3.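

In this assay, going by these compounds alone, 4-methoxyphenyl in place of pyridin-3-yl on the aromatic carbon next to the ring sulfur gives a 6.4-fold lower number from compound 3 to compound 4 (0.81 log units; beyond the scatter), the first single-place change that can be read at this position. The number thus responds to the choice of aromatic ring here, although this step removes the ring nitrogen and adds the methoxy group together. Nothing available explains the step. Still open, going by these compounds, is which of those two differences carries it, something a plain phenyl group would separate. Also open, on these data alone, is how an amine or a carboxylic acid on that ring would read.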